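Swapping the pyridine substituent on compound 3

The source may hold more compounds than are shown below. What is called first, only, known or untested is meant among the compounds shown, and "the series" means these compounds.

Measured so far:
- Compound 1 `CNCc1cc(-c2cccnc2C#N)n(S(=O)(=O)c2ccccc2)c1`: 99%
- Compound 2 `CNCc1cc(-c2cccnc2F)n(S(=O)(=O)c2cccnc2)c1`: 96%
- Compound 3 `CNCc1cc(-c2cccnc2C#N)n(S(=O)(=O)c2cccnc2)c1`: 48%

In a functional assay on the whole organism (strain Jcl:SD) for inhibition, with Rattus norvegicus as the target, with stated times of 3 min and 3 h, at a dose of 1 mg/kg by the intravenous route (on this read-out higher numbers stand for more inhibition at the one dose given (going by the name of the read-out) and lower numbers for less inhibition), compound 3 stands lowest of the three. The change from compound 1 shows a number 51 percentage points lower from compound 1 to compound 3 (beyond the scatter), and that from compound 2 shows a number 48 percentage points lower from compound 2 to compound 3 (beyond the scatter). Compound 4 `CNCc1cc(-c2cnccc2C)n(S(=O)(=O)c2cccnc2)c1` arises from compound 3 by the change (4-methylpyridin-3-yl in place of 2-cyanopyridin-3-yl on an aromatic carbon). The step from compound 2 bears on it directly, since the nitrile that entered there leaves here; the step from compound 1 only shows how strongly a single change on this part of the molecule can move the read-out. For the measured compounds named here, no measured step covers the methyl or the shifted ring nitrogen, so the expectation is a gain of a number 27 percentage points higher from compound 3 to compound 4 (beyond the scatter) in this assay, with wide uncertainty. Compound 4 is therefore estimated at 75%, between 40% and 98%.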

Compound 4, a percentage reported as inhibition, in the whole organism at one dose (the size of the read-out at that dose, not a potency): -54%
Beside the measured number, compound 4's estimate is 129 percentage points above it; the measured number lies below the stated range.
By their numbers in this assay, from the lowest: compound 4; then compound 3; then compounds 2 and 1 (each within the scatter of the next).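

Compound 4 shows that a change at this position can take the read-out in this assay past zero, not merely lower it. Its value of -54% comes with a number 102 percentage points lower from compound 3 to compound 4 (beyond the scatter) and a number 150 percentage points lower from compound 2 to compound 4 (beyond the scatter), so the 4-methylpyridin-3-yl group stands apart from both the nitrile and the fluoro pyridines. Nothing measured here explains this fall. Open, on these data alone, is whether the methyl or the changed place of the ring nitrogen matters more, as the two arrive together. A plain pyridin-3-yl or a 4-methylphenyl group at this place would separate them.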